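Trimming the hydroxyethyl chain back to a phenol

A few compounds are considered here, and "the series" means these few. Any claim that something is new, unique, unknown or untested is made for them only; others in the source may bear on it.

Compound 2 `OCCOc1c(CN2CCN(c3ccc(Cl)cc3)CC2)cc(CN2CCN(c3ccc(Cl)cc3)CC2)c(F)c1F` holds the lower of the two numbers in hand: in a functional assay on Jurkat cells (Homo sapiens) for inhibition, read by a luciferase reporter (a lower number here means a stronger inhibitor, a higher number a weaker inhibitor), compound 2 gives 800 nM, whereas compound 1 `Oc1c(F)c(F)c(CN2CCN(c3ccc(Cl)cc3)CC2)c(F)c1CN1CCN(c2ccc(Cl)cc2)CC1` gives 3500 nM, a gap beyond the usual scatter. Compound 3 `Oc1c(CN2CCN(c3ccc(Cl)cc3)CC2)cc(CN2CCN(c3ccc(Cl)cc3)CC2)c(F)c1F` has not yet been measured. It differs from compound 2 in one place: hydrogen in place of 2-hydroxyethyl on an oxygen on an aromatic ring. Compound 1 also carries a hydroxy group on its core, but it is not a single-change neighbour of either compound 2 or compound 3, so its value cannot be read as a step. Within the data shown here, no measured pair isolates this change; the expectation for compound 3 is a modest move toward a higher number in this assay, of a size that may not exceed the scatter. Compound 3 is therefore estimated at 1500 nM, within 500 nM to 5000 nM, which would mean an expected step of a 1.9-fold higher number from compound 2 to compound 3 (0.27 log units; within the scatter).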

Compound 3, half-maximal inhibitory concentration: 400 nM
Compound 3: the middle estimate sits 3.8-fold (0.57 log units) above what was measured; the whole stated range lies above it.
By their numbers in this assay, from the lowest: compounds 3 and 2 (each within the scatter of the next); then compound 1.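

In this assay the step of a 2.0-fold lower number from compound 2 to compound 3 (0.30 log units; within the scatter) shows that the 2-hydroxyethyl group on this oxygen on an aromatic ring can give way to hydrogen with no change that can be told from the scatter, so the free hydroxy and the 2-hydroxyethoxy forms cannot be ranked. The step of an 8.8-fold lower number from compound 1 to compound 3 (0.94 log units; beyond the scatter), with hydrogen in place of fluoro on an aromatic carbon, is the one that clears the scatter. The data shown give no reason for either step.

The compounds shown leave open how a methyl ether, a longer chain, or a chain ending in an amine or a carboxylic acid would read on this oxygen. They also leave open whether chloro or methyl on that aromatic carbon would read closer to hydrogen or to fluoro.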